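Nitro in place of hydroxy on a naphthyloxy acetohydrazone

This account rests on a few compounds, and the source may have more. Where it says the series, first, only, none or still open, it means among the compounds named here.

Measured compounds:
compound 1 `O=C(COc1cccc2ccccc12)N/N=C/c1ccc(O)cc1` gives 3.73
compound 2 `O=C(COc1cccc2ccccc12)N/N=C/c1cccc(O)c1` gives 3.73

Among the compounds with values here, in a physicochemical assay for lipophilicity, measured as octanol-water partition (on this read-out higher numbers stand for higher lipophilicity and lower numbers for lower lipophilicity), compound 1 stands level with compound 2; the only measured step, no change at the digits printed from compound 1 to compound 2 (within the scatter), moves a hydroxy group from one position on the phenyl ring to another and leaves the value unchanged within the scatter. Compound 3 `O=C(COc1cccc2ccccc12)N/N=C/c1ccc([N+](=O)[O-])cc1` has not yet been measured. It differs from compound 1 in one place: nitro in place of hydroxy on an aromatic carbon. Within the data shown here, no measured step shows this kind of exchange; the single step available, no change at the digits printed from compound 1 to compound 2 (within the scatter), only shifts the hydroxy group and therefore says nothing about replacing it with a nitro group. The expectation for compound 3 in this assay thus rests on the structural change alone, with a hydrogen-bond donor leaving and two hydrogen-bond acceptors entering. A modest step upward, somewhat beyond the scatter, is expected, given as a number 0.37 log units higher from compound 1 to compound 3 (beyond the scatter). Compound 3 is estimated at 4.1 in this assay, with a range from 3.7 to 4.5.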

Compound 3, partition coefficient: 3.97
The estimate for compound 3 lay 0.13 log units above the measured number; the measured number falls inside the stated range.
By their numbers in this assay, from the lowest: compounds 1, 2 and 3 (each within the scatter of the next).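

Compound 2 only moved the hydroxy group around the ring, whereas compound 3 removes it and puts a different group in its place. In this assay, within the data shown here, that exchange of hydroxy for nitro gives a number 0.24 log units higher from compound 1 to compound 3 (within the scatter) and so adds a first look at a change of group rather than a change of position. On this aromatic carbon, para to a large group, a hydroxy with one hydrogen-bond donor and one acceptor can therefore give way to a nitro with no donor, two acceptors and more heavy atoms while the reading stays within the usual spread of repeat measurements, though nothing available here offers an explanation for this.

The compounds shown leave open whether an amine, a carboxylic acid or a longer chain on this same aromatic carbon would also stay within that spread. They also leave open whether nitro would give a similar reading at the place the hydroxy holds in compound 2, since this exchange is seen at a single position on a single core.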